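Phenyl in place of cyclopropyl: compound 2 to compound 4

The source may hold more compounds than are shown below. What is called first, only, known or untested is meant among the compounds shown, and "the series" means these compounds.

Measured in a functional assay on KB cells (Homo sapiens) for cytotoxicity, read by MTT assay, with a stated time of 72 h; on this read-out higher numbers stand for an effect only at larger amounts of compound and lower numbers for an effect already at smaller amounts:
- compound 1 `COc1cccc(Nc2cc(-c3ccccc3)oc(=O)c2)c1` gives 0.49 uM
- compound 2 `O=c1cc(NC2CC2)cc(-c2ccccc2)o1` gives > 30 uM (a limit, not a number)
- compound 3 `COc1ccc(Nc2cc(C3CCCCC3)oc(=O)c2)cc1` gives 8.32 uM

Compound 2 gives no number, and its reading is only a limit, namely (the limit of > 30 uM in this assay, at which 1 of the 3 values shown sits). Compound 4 `O=c1cc(Nc2ccccc2)cc(-c2ccccc2)o1` is not yet measured. It differs from compound 2 as follows: phenyl in place of cyclopropyl on a nitrogen on an aromatic ring. In words, this is phenyl in place of cyclopropyl on a nitrogen on an aromatic ring.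

For the measured compounds named here, no measured step isolates this change, so the expectation rests on two neighbours that also carry an aromatic ring on that nitrogen. Compound 1 gives 0.49 uM and compound 3 gives 8.32 uM. Both return numbers, although they lie well apart. A large expected move toward lower numbers in this assay is estimated as an at least 15-fold lower number from compound 2 to compound 4 (1.17 log units; beyond the scatter). For compound 4 the estimated value is 2 uM, with an expected range of 0.4 uM to 10 uM.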

Compound 4, concentration for half-maximal effect: 0.13 uM
Compound 4: middle estimate off by 15-fold (1.19 log units), on the high side; the measured number lies below the stated range.
By their numbers in this assay, from the lowest: compound 4; then compound 1; then compound 3. At a limit, above all of these: compound 2.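

In this assay, for the compounds shown here, phenyl in place of cyclopropyl on a nitrogen on an aromatic ring gives an at least 230-fold lower number from compound 2 to compound 4 (2.36 log units; beyond the scatter) and is the only measured step for this change at this position. The step is a bound and not an exact size, because compound 2 gives only a limit: the limit of > 30 uM in this assay, at which 1 of the 4 values shown sits. The methoxy group of compound 1 is not required for a low number, as hydrogen in place of methoxy on an aromatic carbon gives a 3.8-fold lower number from compound 1 to compound 4 (0.58 log units; beyond the scatter) in this pair.

Going by these compounds, whether an aromatic ring directly on that nitrogen is what counts remains open; a benzyl group or a longer chain such as n-butyl there would test this. Also open, on these data alone, is how a group other than methoxy on that phenyl, such as fluoro or a carboxylic acid, would compare with compound 4.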